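This account rests on a few compounds, and the source may have more. Where it says the series, first, only, none or still open, it means among the compounds named here.

Measured compounds:
Compound 1 `COc1ccc(-c2cn3ccnc3c(-c3ccc4ncn(C5CCCCC5)c4c3)n2)cc1`: 68.6%
Compound 2 `c1cn2cc(-c3ccc4c(c3)ncn4C3CCCCC3)nc(-c3ccc4ncn(C5CCCCC5)c4c3)c2n1`: 25.3%

Both numbers come from a functional assay on A549 cells (Homo sapiens) for inhibition, read by sulforhodamine B assay, with a stated time of 48 h, tested at 10 uM; a lower number here means less inhibition, a higher number more inhibition at the concentration tested (going by the name of the read-out). Compound 2 stands lowest of the two; its nearest neighbour is compound 1, whose value lies higher by a margin beyond the usual scatter. Compound 3 `c1ccc(Cn2cnc3ccc(-c4nc(-c5ccc6c(c5)ncn6C5CCCCC5)cn5ccnc45)cc32)cc1` is not yet measured. It differs from compound 2 in one place: benzyl in place of cyclohexyl on an aromatic nitrogen. Going by the values given here, no pair of measured compounds shows the effect of such a change, so the data give no direction for it. The expected step of a number 4.7 percentage points higher from compound 2 to compound 3 (within the scatter) is therefore none beyond the scatter. Compound 3 is estimated at 30%, within a range of 10% to 60%.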

Compound 3, a percentage reported as inhibition, at one concentration (the size of the read-out at that concentration, not a potency): -5.05%
The estimate for compound 3 lay 35.1 percentage points above the measured number; the measured number lies below the stated range.
By their numbers in this assay, from the lowest: compound 3; then compound 2; then compound 1.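

In this assay, the group on this aromatic nitrogen matters: benzyl in place of cyclohexyl gives a number 30.4 percentage points lower from compound 2 to compound 3 (beyond the scatter). Compound 3 stands at -5.05%, so this single change leaves no inhibition to read at the concentration tested. Nothing shown explains the loss.

The change swaps a non-aromatic ring for an aromatic one and also adds a carbon, and these two differences cannot be told apart here. Going by these compounds, a cyclohexylmethyl or phenyl group on the same nitrogen would separate them, while the effect of an amine-bearing chain there remains open.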